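A few compounds are considered here, and "the series" means these few. Any claim that something is new, unique, unknown or untested is made for them only; others in the source may bear on it.

Compound 3, `C=Cc1cc(CNC(=S)CCc2ccc(C(C)(C)C)cc2)cc(F)c1NS(C)(=O)=O`, gives 32 nM in a functional assay for antagonist activity at transient receptor potential cation channel subfamily V member 1 (Rattus norvegicus); on this read-out lower numbers stand for stronger inhibition and higher numbers for weaker inhibition. That is the lowest of the three numbers recorded so far, but only partly in a meaningful way: compound 2, `C=Cc1cc(CNC(=S)CCc2ccc(C(C)(C)C)cc2)ccc1NS(C)(=O)=O`, gives 61 nM, and the step of a 1.9-fold lower number from compound 2 to compound 3 (0.28 log units; within the scatter) stays within the scatter, so these two cannot be ranked. Compound 1, `CC(C)(C)c1ccc(CCC(=S)NCc2ccc(NS(C)(=O)=O)c(I)c2)cc1`, gives 300 nM, and here the gap to compound 3 is beyond the scatter.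

Compound 4, `CC(C)(C)c1ccc(CCC(=S)NCc2cc(F)c(NS(C)(=O)=O)c(C#N)c2)cc1`, differs from compound 3 by a single exchange: cyano in place of vinyl on an aromatic carbon. For the measured compounds named here, two measured steps bear on this. The step of a 4.9-fold lower number from compound 1 to compound 2 (0.69 log units; beyond the scatter) exchanged one small group for another at this same aromatic carbon and gave a modest shift beyond the scatter, showing that this position is sensitive. The step of a 1.9-fold lower number from compound 2 to compound 3 (0.28 log units; within the scatter) changed a different carbon and stayed within the scatter. Going by the values given here, no measured pair exchanges vinyl for cyano, so the direction is open; a shift around the edge of the scatter, or none, is expected. Compound 4 is therefore estimated at 55 nM, with a range from 15 nM to 200 nM, which would mean a 1.7-fold higher number from compound 3 to compound 4 (0.24 log units; within the scatter).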

Compound 4, half-maximal inhibitory concentration: 28 nM
Estimate against measurement, compound 4: 2.0-fold (0.29 log units) above; the measured number falls inside the stated range.
By their numbers in this assay, from the lowest: compounds 4, 3 and 2 (each within the scatter of the next, the first and the last beyond it); then compound 1.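

In this assay, the exchange gives a 1.1-fold lower number from compound 3 to compound 4 (0.06 log units; within the scatter) and so leaves compound 3 and compound 4 impossible to tell apart. The aromatic carbon ortho to a methanesulfonamido group therefore tolerates cyano as well as vinyl, even though cyano brings a triple bond and a hydrogen-bond acceptor, whereas vinyl brings a double bond and no acceptor. This carbon does not treat every group alike, however, as the earlier exchange of iodo for vinyl gave a 4.9-fold lower number from compound 1 to compound 2 (0.69 log units; beyond the scatter) and that step lies beyond the scatter.

Nothing available explains why vinyl and cyano read alike here. Also open, as far as these compounds go, is how an amine, a carboxylic acid or a longer chain on this aromatic carbon would read in this assay, and whether cyano would match vinyl without the fluoro group.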